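Pyridine swap on the carbonyl of a benzimidazole series

The source may hold more compounds than are shown below. What is called first, only, known or untested is meant among the compounds shown, and "the series" means these compounds.

Of the compounds shown here, three of one core have been measured in an ADME assay on HEK-293T cells (Homo sapiens) for cytotoxicity, read by MTT assay, with a stated time of 24 h; on this read-out higher numbers stand for lower toxicity in this test and lower numbers for higher toxicity in this test. Compound 1 `Cc1ccc(-c2nn(-c3ccccc3)cc2-c2nc3ccccc3n2C(=O)c2ccc(Cl)cc2)cc1` gives 216000 nM, compound 2 `Cc1ccc(-c2nn(-c3ccccc3)cc2-c2nc3ccccc3n2C(=O)c2ccc(C)nc2)cc1` gives 145000 nM, and compound 3 `Cc1cncc(C(=O)n2c(-c3cn(-c4ccccc4)nc3-c3ccc(C(F)(F)F)cc3)nc3ccccc32)c1` gives 123000 nM. For the measured compounds named here, the only single-point step among them, a 1.5-fold lower number from compound 1 to compound 2 (0.17 log units; within the scatter), shows that exchanging the aryl group on the carbonyl carbon left the read-out essentially unchanged. Compound 3 sits at one end of this narrow span, with compound 2 and compound 1 both within the usual scatter of it, so no real separation between the three can be claimed.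

Compound 4 `O=C(c1ccncc1)n1c(-c2cn(-c3ccccc3)nc2-c2ccc(C(F)(F)F)cc2)nc2ccccc21` differs from compound 3 in one place: pyridin-4-yl in place of 5-methylpyridin-3-yl on a carbonyl carbon. The change again touches only the aryl group on the carbonyl carbon, the same site that was varied between compound 1 and compound 2, where the measured step stayed within the scatter. Going by the values given here, no measured step bears on shifting a methyl or the nitrogen position within a pyridine ring, so the expectation rests on that one step alone. For compound 4 the step of a 1.0-fold lower number from compound 3 to compound 4 (0.01 log units; within the scatter) is therefore expected to be small, with no clear direction beyond the scatter. Compound 4 is estimated to give 120000 nM in this assay, within a range of 55000 nM to 260000 nM.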

Compound 4, half-maximal cytotoxic concentration: 135000 nM
Compound 4: the middle estimate sits 1.1-fold (0.05 log units) below what was measured, and the stated range covers the measured number.
By their numbers in this assay, from the lowest: compounds 3, 4, 2 and 1 (each within the scatter of the next).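

In this assay, a 1.1-fold higher number from compound 3 to compound 4 (0.04 log units; within the scatter) shows that this position also tolerates an exchange of one pyridine for another on the carbonyl carbon, with the read-out remaining within the scatter. The earlier step at this site replaced 4-chlorophenyl with 6-methylpyridin-3-yl, so it could not show what happens when the ring stays a pyridine, the methyl is lost and the attachment changes from pyridin-3-yl to pyridin-4-yl. No independent measurement accounts for this flat result, and nothing available gives a reason for it.

The step changes the methyl and the attachment of the pyridine together, so the compounds shown cannot separate what each contributes, and either could offset the other within the scatter. Every group shown on this carbonyl carbon is a six-membered aromatic ring, which leaves open whether a different kind of group there, such as a piperidine, a chain ending in a carboxylic acid or a longer alkyl chain, would move the read-out beyond the scatter.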